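A few compounds are considered here, and "the series" means these few. Any claim that something is new, unique, unknown or untested is made for them only; others in the source may bear on it.

Compound 2 `Oc1nnc(-c2ccccc2Oc2ccccc2F)o1` is the hydroxy analogue of compound 1 `Nc1nnc(-c2ccccc2Oc2ccccc2F)o1`. In a functional assay on the whole organism with Mus musculus as the target, in the maximal electroshock model (a higher number here means that more compound is needed for the effect, a lower number that less compound is needed), compound 2 gives only a limit, > 100 mg/kg, and no number. In this assay compound 1 gives 9.57 mg/kg. For the measured compounds named here, the one step measured, an at least 10-fold higher number from compound 1 to compound 2 (1.01 log units; beyond the scatter), ends at the limit (the limit of > 100 mg/kg in this assay, at which 1 of the 2 values shown sits), so its true size is open-ended. Compound 3 `Fc1ccccc1Oc1ccccc1-c1n[nH]c(S)n1` carries 5-sulfanyl-1H-1,2,4-triazol-3-yl in place of 5-hydroxy-1,3,4-oxadiazol-2-yl on an aromatic carbon. Going by the values given here, no measured step covers an exchange of the five-membered ring as a whole; the only step in hand, an at least 10-fold higher number from compound 1 to compound 2 (1.01 log units; beyond the scatter), concerns a single substituent on that ring and took compound 2 out of the measurable range. With compound 2 sitting at a limit, a step from it can only be expected as a gain or as none; the expected step of an at least 1.6-fold lower number from compound 2 to compound 3 (0.22 log units; that floor lies within the scatter) is set as a modest gain, with a real chance that compound 3 again returns only a limit. Compound 3 is estimated at 60 mg/kg, in a range from 15 mg/kg to 200 mg/kg.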

Compound 3, dose for half-maximal effect: 92 mg/kg
For compound 3 the middle estimate is 1.5-fold (0.19 log units) below the measured one; the measured number falls inside the stated range.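

The 5-sulfanyl-1H-1,2,4-triazol-3-yl group gives a number in this assay, but it does not reach the level of the 5-amino-1,3,4-oxadiazol-2-yl group: the exchange gives a 9.6-fold higher number from compound 1 to compound 3 (0.98 log units; beyond the scatter). Compound 1 therefore keeps the lowest number of the three, with its steps to both other compounds beyond the scatter, and on this position the amino-bearing ring group is the only one of the three that holds a clear advantage. Against the 5-hydroxy-1,3,4-oxadiazol-2-yl group the exchange gives an at least 1.0-fold lower number from compound 2 to compound 3 (0.03 log units; that floor lies within the scatter), so no gain can be claimed, and the true size of the step stays open: the limit of > 100 mg/kg in this assay, at which 1 of the 3 values shown sits.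

The exchange alters the ring and its substituent together, so the effects of the two cannot be separated here; a 5-amino-1H-1,2,4-triazol-3-yl or a 5-sulfanyl-1,3,4-oxadiazol-2-yl group on the shared core would divide them. Also open, as far as these compounds go, is whether the amino group of compound 1 must stay unsubstituted, which a methylamino or an acetamido group in its place would test.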